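Swapping pyridin-3-yl for 4-chloro-2-methylphenyl at the carbonyl

The compounds below may be only part of what the source reports. "The series", "measured", "known", "first", "only" and "open" are said of these compounds alone.

In a functional assay on MDA-MB-231 cells (Homo sapiens) for antiproliferative activity, read by MTT assay, with stated times of 72 h and 4 h (a higher number here means a weaker inhibitor, a lower number a stronger inhibitor), compound 1 (`O=C(Nc1ccc(Cl)c(-c2nnc3c(Cl)cccn23)c1)c1ccccn1`) gives 92000 nM. Compound 2 (`Cc1nc(C(=O)Nc2ccc(Cl)c(-c3nnc4c(Cl)cccn34)c2)cs1`) gives > 100000 nM, which is a limit and not a number. Compound 3 (`O=C(Nc1ccc(Cl)c(-c2nnc3c(Cl)cccn23)c1)c1cccnc1`) also gives only a limit, > 100000 nM. Compound 3 therefore stands at the limit of > 100000 nM in this assay, at which 2 of the 3 values shown sit. Compound 4 (`Cc1cc(Cl)ccc1C(=O)Nc1ccc(Cl)c(-c2nnc3c(Cl)cccn23)c1`) carries 4-chloro-2-methylphenyl in place of pyridin-3-yl on a carbonyl carbon. The measured steps change this same place, yet they say little: there is an at least 1.0-fold higher number from compound 1 to compound 3 (0.03 log units; that floor lies within the scatter), and there is an at least 1.0-fold higher number from compound 1 to compound 2 (0.03 log units; that floor lies within the scatter). Only a small step toward a lower number, or none beyond the scatter, is therefore expected in this assay. The expected change is an at least 1.6-fold lower number from compound 3 to compound 4 (0.22 log units; that floor lies within the scatter). Compound 4 is estimated at 60000 nM, with an expected range of 15000 nM to 100000 nM.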

Compound 4, half-maximal inhibitory concentration: > 100000 nM
Compound 4: no number, only a limit (the forecaster's own chance of this, stated with the estimate: 45%); middle value at least 1.6-fold (0.22 log units) away from the limit.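

Compound 4 shows that a six-membered aromatic ring of carbon only, 4-chloro-2-methylphenyl, fares no better at this carbonyl carbon than the rings carrying a hetero atom, and it too gives only a limit in this assay: the limit of > 100000 nM in this assay, at which 3 of the 4 values shown sit.

The steps to compound 4 from compound 2 and compound 3 cannot be read, as both ends are limits. Within the data shown here, the one readable step is an at least 1.0-fold higher number from compound 1 to compound 4 (0.03 log units; that floor lies within the scatter).

Going by these compounds, whether a simple amine or a carboxylic acid at this place, or a longer alkyl chain, would give a measurable number remains open.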